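Hydroxy added to compound 1: working notes

The source may hold more compounds than are shown below. What is called first, only, known or untested is meant among the compounds shown, and "the series" means these compounds.

- compound 1 `COc1ccc(-n2cnnc2-c2cc(OC)c(OC)c(OC)c2)cc1`: 4370 nM
- compound 2 `COc1cc(-c2nncn2-c2ccc(N(C)C)cc2)cc(OC)c1OC`: 219 nM

Still unmeasured is compound 3 `COc1ccc(-n2cnnc2-c2cc(OC)c(OC)c(OC)c2)cc1O`. In a functional assay on LOX IMVI cells (Homo sapiens) for inhibition (on this read-out lower numbers stand for stronger inhibition of growth and higher numbers for weaker inhibition of growth), compound 1 stands highest of the two measured numbers, at 4370 nM. The change to compound 3 is hydroxy in place of hydrogen on an aromatic carbon, ortho to a methoxy group and meta to a large group. Among the compounds with values here, one measured step bears on it, and only indirectly: a 20-fold lower number from compound 1 to compound 2 (1.30 log units; beyond the scatter), a large step with dimethylamino in place of methoxy on an aromatic carbon. That is a different substitution, so it gives a scale and not a prediction. Within the data shown here, no hydroxy compound has been measured, so the range stays wide. A lower number is expected, by a smaller step than that one. The expected change is an 11-fold lower number from compound 1 to compound 3 (1.04 log units; beyond the scatter). For compound 3 the estimate is 400 nM, with an expected range of 50 nM to 3000 nM.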

Compound 3, concentration for 50% growth inhibition: 550 nM
Compound 3: middle estimate off by 1.4-fold (0.14 log units), on the low side, and the stated range covers the measured number.
By their numbers in this assay, from the lowest: compound 2; then compound 3; then compound 1.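

In this assay, a 7.9-fold lower number from compound 1 to compound 3 (0.90 log units; beyond the scatter) shows that the series responds at a second place on the aromatic ring that carries the methoxy group of compound 1. The earlier step replaced that methoxy group, whereas here it stays in place and a hydroxy group enters ortho to it, so a gain of a single heavy atom on an aromatic carbon is enough to move the number beyond the scatter. Nothing at hand accounts for this step.

The compounds shown leave open whether the effect is particular to hydroxy or would also appear with an amine, fluorine or a longer chain such as ethoxy at the same place. They also leave open whether hydroxy at this place and dimethylamino in place of the methoxy group would combine on one ring.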